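The source may hold more compounds than are shown below. What is called first, only, known or untested is meant among the compounds shown, and "the series" means these compounds.

In an assay on membranes from HeLa cells for displacement of a labelled ligand from adenosine receptor A3 (Homo sapiens), read by scintillation counting, with a stated time of 180 min, tested at 1 uM (a lower number here means less inhibition, a higher number more inhibition at the concentration tested (going by the name of the read-out)), compound 1 `CC1=C(C(=O)C2CC2)C(c2ccco2)NC(=O)N1` gives 7% and compound 2 `CC1=C(C(=O)C2CC2)C(c2ccoc2)NC(=O)N1` gives 16%. Among the compounds with values here, the one measured step, a number 9 percentage points higher from compound 1 to compound 2 (within the scatter), stays within the scatter, so compound 2 sits at the top of these two numbers only by a margin that means nothing. Compound 3 `CCC(CC)OC(=O)C1=C(C)NC(=O)NC1c1ccoc1` differs from compound 2 by (pentan-3-yl)oxy in place of cyclopropyl on a carbonyl carbon. Within the data shown here, no measured step concerns a change at this carbonyl carbon, so the expected shift is a number 2 percentage points lower from compound 2 to compound 3 (within the scatter), nothing beyond the scatter. For compound 3 the estimated value is 14%, expected to fall between 0% and 35%.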

Compound 3, a percentage reported as inhibition, at one concentration (the size of the read-out at that concentration, not a potency): 5%
Compound 3: the middle estimate sits 9 percentage points above what was measured, within the range that was stated.
By their numbers in this assay, from the lowest: compounds 3, 1 and 2 (each within the scatter of the next, the first and the last beyond it).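

Within the data shown here, this is the first measured change at this carbonyl carbon: in this assay, (pentan-3-yl)oxy in place of cyclopropyl gives a number 11 percentage points lower from compound 2 to compound 3 (beyond the scatter). The number at this position can therefore move with the group it carries, which the furan-3-yl for furan-2-yl change did not show, since that step stayed within the scatter. Nothing available explains this step.

The compounds shown do not separate the part played by the oxygen from that of the pentan-3-yl chain. They also leave open how a methoxy group or a dimethylamino group on this carbonyl carbon would read, and whether the step holds with furan-2-yl.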